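The source may hold more compounds than are shown below. What is called first, only, known or untested is meant among the compounds shown, and "the series" means these compounds.

Compound 2, `COc1cc(NC(C)CCCNC(=O)Nc2ccc(F)cc2)c2ncccc2c1`, is measured in a functional assay on L1210 cells (Mus musculus) for inhibition, read by MTT assay, with a stated time of 72 h (a higher number here means a weaker inhibitor, a lower number a stronger inhibitor), at 18000 nM. Among the three compounds measured, compound 2 is level with compound 1, `COc1cc(NC(C)CCCNC(=O)NNC(=O)Nc2cc(C(F)(F)F)cc(C(F)(F)F)c2)c2ncccc2c1`, which gives 18000 nM, and the two together hold the lowest numbers; compound 3, `COc1cc(NC(C)CCCNC(=O)NNC(=O)Nc2ccc(O)cc2)c2ncccc2c1`, gives 95000 nM.

Compound 4, `COc1cc(NC(C)CCCNC(=O)NNC(=O)Nc2cccc(Cl)c2)c2ncccc2c1`, has not yet been measured. Compared with compound 2 it differs in one place: ((3-chlorophenyl)carbamoyl)amino in place of 4-fluorophenyl on an amide-type nitrogen. Among the measured compounds shown here, the one measured step that resembles this change is the one from compound 2 to compound 3, where the same 4-fluorophenyl gives way to a longer ((4-hydroxyphenyl)carbamoyl)amino group and the number rises, a 5.3-fold higher number from compound 2 to compound 3 (0.72 log units; beyond the scatter). Compound 1 shows, on the other hand, that the same longer linker carrying a different aryl group ends level with compound 2. The change to compound 4 is therefore expected to cost little, a 1.2-fold higher number from compound 2 to compound 4 (0.09 log units; within the scatter), given the step to compound 3 and the value of compound 1. For compound 4 the expected value is 22000 nM, estimated between 9000 nM and 55000 nM.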

Compound 4, half-maximal inhibitory concentration: 27000 nM
Compound 4: middle estimate off by 1.2-fold (0.09 log units), on the low side, and the stated range covers the measured number.
By their numbers in this assay, from the lowest: compounds 1, 2 and 4 (each within the scatter of the next); then compound 3.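

In this assay, placing the longer ((3-chlorophenyl)carbamoyl)amino group on the amide-type nitrogen in place of 4-fluorophenyl gives a 1.5-fold higher number from compound 2 to compound 4 (0.18 log units; within the scatter) and so shows that this position tolerates the longer group when it carries this aryl end. With the longer group held the same, 3-chlorophenyl in place of 4-hydroxyphenyl gives a 3.5-fold lower number from compound 3 to compound 4 (0.55 log units; beyond the scatter) and so ties the weaker result of compound 3 to its 4-hydroxyphenyl end, not to the longer group alone. Nothing available explains why these two aryl ends differ.

Going by these compounds, whether the place of the chlorine matters remains open, and a 4-chlorophenyl end on the same longer group would test this. Also open, on these data alone, is how an aryl end carrying an amine or a carboxylic acid would behave at this position.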